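This account rests on a few compounds, and the source may have more. Where it says the series, first, only, none or still open, it means among the compounds named here.

In a functional assay on DLA cells (Mus musculus) for cytotoxicity, read by trypan blue exclusion, with a stated time of 48 h (on this read-out lower numbers stand for stronger inhibition and higher numbers for weaker inhibition), compound 1 `Cc1cc(C(=O)c2ccccc2)cc(C)c1OCC(=O)Nc1nc(-c2ccccc2)cs1` gives 19100 nM. Compound 2 `COc1ccc(-c2csc(NC(=O)COc3c(C)cc(C(=O)c4ccccc4)cc3C)n2)cc1` differs from it by methoxy in place of hydrogen on an aromatic carbon, and in this assay compound 2 gives 38400 nM. Compound 3 `Cc1cc(C(=O)c2cccc(Br)c2)ccc1OCC(=O)Nc1nc(-c2ccccc2)cs1` has another core; the difference between the two cores is not broken down here. In this assay compound 3 gives 21700 nM. Compound 4 `COc1ccc(-c2csc(NC(=O)COc3ccc(C(=O)c4cccc(Br)c4)cc3C)n2)cc1` is related to compound 3 by methoxy in place of hydrogen on an aromatic carbon, the same change, at a place described in the same words, as that from compound 1 to compound 2. A step of similar size is expected for compound 4 because a 2.0-fold higher number from compound 1 to compound 2 (0.30 log units; within the scatter). The expected step, beside that earlier one, is a 1.8-fold higher number from compound 3 to compound 4 (0.27 log units; within the scatter). For compound 4 the estimate in this assay is 40000 nM, expected to fall between 20000 nM and 80000 nM.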

Compound 4, half-maximal inhibitory concentration: 35400 nM
Compound 4: middle estimate off by 1.1-fold (0.05 log units), on the high side; the measured number falls inside the stated range.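

Methoxy in place of hydrogen, the change from phenyl to 4-methoxyphenyl, gives in this assay a 1.6-fold higher number from compound 3 to compound 4 (0.21 log units; within the scatter), and this step reads much like the earlier one on the other core. Set side by side, the two steps show no sign that the core alters the outcome of this change: the same change on two cores in this assay, a 2.0-fold higher number (0.30 log units; within the scatter) from compound 1 to compound 2 and a 1.6-fold higher number (0.21 log units; within the scatter) from compound 3 to compound 4, 1.2-fold (0.09 log units) apart, within the scatter of two such steps. Each step on its own lies within the scatter, however, so the pair does not show that methoxy shifts the number at all, and two cores cannot speak for the whole series.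

The compounds shown leave open how other groups at this place would read, such as an amine, a carboxylic acid or a longer chain like butoxy. Going by these compounds, whether any of these would give a step beyond the scatter remains unknown.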